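Cyclohexyl amide as the next step from compound 3

The source may hold more compounds than are shown below. What is called first, only, known or untested is meant among the compounds shown, and "the series" means these compounds.

In a functional assay on SK-BR-3 cells (Homo sapiens) for antiproliferative activity (a higher number here means a weaker inhibitor, a lower number a stronger inhibitor), compound 3 `CCCCC(=O)Nc1cc2ccc(O[C@@H]3OC(C)(C)[C@H](OC)[C@@H](O)[C@H]3O)c(C)c2oc1=O` gives 118000 nM, compound 1 `CO[C@@H]1[C@@H](O)[C@@H](O)[C@H](Oc2ccc3cc(NC(=O)C4CCCC4)c(=O)oc3c2C)OC1(C)C` gives 67000 nM and compound 2 `CO[C@@H]1[C@@H](O)[C@@H](O)[C@H](Oc2ccc3cc(NC(=O)C4CC4)c(=O)oc3c2C)OC1(C)C` gives 517000 nM. Compound 3 therefore stands close to one neighbour, a 1.8-fold higher number from compound 1 to compound 3 (0.25 log units; within the scatter), and well apart from the other, a 4.4-fold lower number from compound 2 to compound 3 (0.64 log units; beyond the scatter).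

Compound 4 `CO[C@@H]1[C@@H](O)[C@@H](O)[C@H](Oc2ccc3cc(NC(=O)C4CCCCC4)c(=O)oc3c2C)OC1(C)C` carries cyclohexyl in place of butyl on a carbonyl carbon. Going by the values given here, two measured steps bear on this change. The exchange of cyclopentyl for butyl is a 1.8-fold higher number from compound 1 to compound 3 (0.25 log units; within the scatter), and the exchange of cyclopentyl for cyclopropyl is a 7.7-fold higher number from compound 1 to compound 2 (0.89 log units; beyond the scatter). This single pair of ring amides favours cyclopentyl over cyclopropyl, so compound 4 is expected to fall near compound 1 rather than near compound 2. The expected change is a 2.0-fold lower number from compound 3 to compound 4 (0.29 log units; within the scatter), a small move towards a lower number in this assay that may not clear the scatter. For compound 4 the estimated value is 60000 nM, with an expected range from 22000 nM to 140000 nM.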

Compound 4, half-maximal inhibitory concentration: 46800 nM
Compound 4: the middle estimate sits 1.3-fold (0.11 log units) above what was measured; low and high end bracket the measured number.
By their numbers in this assay, from the lowest: compounds 4, 1 and 3 (each within the scatter of the next, the first and the last beyond it); then compound 2.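

Against the open chain, cyclohexyl gives a step beyond the scatter in this assay (a 2.5-fold lower number from compound 3 to compound 4 (0.40 log units; beyond the scatter)), whereas the cyclopentyl amide stayed within the scatter of the butyl amide (a 1.8-fold higher number from compound 1 to compound 3 (0.25 log units; within the scatter)). Cyclohexyl also gives the largest step in the series so far against the cyclopropyl amide (an 11-fold lower number from compound 2 to compound 4 (1.04 log units; beyond the scatter)). The two larger rings cannot be told apart (a 1.4-fold lower number from compound 1 to compound 4 (0.16 log units; within the scatter)), so among the cyclopropyl, cyclopentyl and cyclohexyl amides, the separation lies between cyclopropyl and the two larger rings, with no further gain readable from cyclopentyl to cyclohexyl.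

Still open, on these data alone, is whether cycloheptyl, a phenyl ring, or a cyclohexyl ring bearing an amine or a carboxylic acid would shift the number further. No measurement here gives a reason for these differences.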